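The source may report more compounds than this note shows. Statements on the series, on what has been measured and on what is new or still open speak of the compounds shown alone.

In a functional assay on DU-145 cells (Homo sapiens) for inhibition, read by trypan blue exclusion, with a stated time of 96 h (a higher number here means a weaker inhibitor of growth, a lower number a stronger inhibitor of growth), compound 1 `O=C(/C(=C\c1ccc(F)c([N+](=O)[O-])c1)S(=O)(=O)c1ccc(Br)cc1)c1ccc(Br)cc1` gives 25000 nM and compound 2 `O=C(/C(=C\c1ccc(O)c([N+](=O)[O-])c1)SCc1ccc(Br)cc1)c1c(F)c(F)c(F)c(F)c1F` gives 10000 nM. Compound 3 `O=C(/C(=C\c1ccc(O)c([N+](=O)[O-])c1)S(=O)(=O)Cc1ccc(Br)cc1)c1c(F)c(F)c(F)c(F)c1F` gives 50000 nM, which is within the scatter of compound 1 and beyond the scatter of compound 2.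

Compound 4 `O=C(/C(=C\c1ccc(O)c([N+](=O)[O-])c1)S(=O)(=O)Cc1ccc(Br)cc1)c1ccc(Br)cc1` differs from compound 3 by 4-bromophenyl in place of 2,3,4,5,6-pentafluorophenyl on a carbonyl carbon. Among the measured compounds shown here, no measured step makes this exchange. For the measured compounds named here, the only measured step, a 5.0-fold higher number from compound 2 to compound 3 (0.70 log units; beyond the scatter), places (4-bromobenzyl)sulfonyl in place of (4-bromobenzyl)sulfanyl and so bears on it only indirectly, as a sense of step size. Compound 1 also has 4-bromophenyl on a carbonyl carbon and gives 25000 nM, but it differs from compound 3 in other places too, so the comparison is loose.

No step beyond the scatter is therefore expected in this assay. The expected change is a 1.7-fold lower number from compound 3 to compound 4 (0.22 log units; within the scatter). For compound 4 the estimated value is 30000 nM, with an expected range of 10000 nM to 90000 nM.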

Compound 4, concentration for 50% growth inhibition: 10000 nM
For compound 4 the middle estimate is 3.0-fold (0.48 log units) above the measured one, within the range that was stated.
By their numbers in this assay, from the lowest: compounds 2 and 4 (each within the scatter of the next); then compounds 1 and 3 (each within the scatter of the next).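

With (4-bromobenzyl)sulfonyl held constant, the group on the carbonyl carbon now has a measured step of its own: 4-bromophenyl in place of 2,3,4,5,6-pentafluorophenyl gives a 5.0-fold lower number from compound 3 to compound 4 (0.70 log units; beyond the scatter) in this assay. Among the compounds shown here, until now, the only single-place step lay at the sulfur-linked chain, so this position was untested, and it now proves able to move the growth-inhibition number beyond the scatter. The two groups have the same counts of hydrogen-bond donors and acceptors and the same net charge, so those counts do not separate them, and no measurement at hand accounts for the step.

As far as these compounds go, whether this exchange gives a step of similar size with (4-bromobenzyl)sulfanyl in the chain remains open. Also open, from the compounds shown here alone, is how an unsubstituted phenyl or a 4-chlorophenyl on the carbonyl carbon would compare.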